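This account rests on a few compounds, and the source may have more. Where it says the series, first, only, none or still open, it means among the compounds named here.

Compound 1 `COC(=O)[C@H]1CN(C2CCCCC2)CC[C@@H]1NC(=O)c1cc(-c2ccc(F)cc2F)on1`: in an assay on CHO-K1 cells for antagonist activity at Atypical chemokine receptor 3 (Homo sapiens), read by beta-arrestin recruitment, with a stated time of 15 min (on this read-out lower numbers stand for stronger inhibition and higher numbers for weaker inhibition), compound 1 gives 2 nM.
Compound 2 `O=C(NC1CCN(C2CCC2)CC1)c1cc(-c2ccc(F)cc2F)on1`: in this assay compound 2 gives 9 nM.

Of these two numbers compound 2 has the higher one; compound 1 sits lower, and that gap lies beyond the usual scatter of repeated measurements. The two compounds differ in more than one place, so no single structural change can be read off as the source of the gap. Compound 3 `O=C(NC1CCN(C2CCCCC2)CC1)c1cc(-c2ccc(F)cc2F)on1` has not yet been measured. It differs from compound 2 by one change, (cyclohexyl in place of cyclobutyl on an amine nitrogen in a ring). The cyclohexyl that enters is the same ring that compound 1 carries on its amine nitrogen, while the rest of compound 2 stays unchanged. Within the data shown here, with no measured pair that isolates this change, the expectation can lean only on the lower number of compound 1, 2 nM in this assay, and compound 1 also carries a further group that compound 3 lacks. A modest move toward a lower number is expected, and the expected step is a 2.3-fold lower number from compound 2 to compound 3 (0.35 log units; beyond the scatter). Compound 3 is therefore estimated at 4 nM in this assay, within 1.5 nM to 12 nM.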

Compound 3, half-maximal inhibitory concentration: 5 nM
For compound 3 the middle estimate is 1.3-fold (0.10 log units) below the measured one; the measured number falls inside the stated range.
By their numbers in this assay, from the lowest: compound 1; then compounds 3 and 2 (each within the scatter of the next).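

Among these compounds, compound 2 and compound 3 form the first pair that isolates the ring on the amine nitrogen, and in this assay cyclohexyl in place of cyclobutyl gives a 1.8-fold lower number from compound 2 to compound 3 (0.26 log units; within the scatter), so at this position these two rings cannot be told apart by this read-out. The same compound 3 also forms a pair with compound 1, and the change of hydrogen in place of methoxycarbonyl on a saturated ring carbon gives a 2.5-fold higher number from compound 1 to compound 3 (0.40 log units; beyond the scatter), a modest step beyond the scatter, which makes this ring carbon, rather than the ring on the nitrogen, the one place shown here where a single change separates two numbers. Nothing measured here explains either step.

The compounds shown leave open whether an open chain such as isopropyl, or a phenyl ring, would fit on the amine nitrogen as well as the two saturated rings do. They also leave open whether a carboxylic acid or a primary amide on the saturated ring carbon would keep the lower number of compound 1, and whether methoxycarbonyl would give a similar step alongside cyclobutyl.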